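A few compounds are considered here, and "the series" means these few. Any claim that something is new, unique, unknown or untested is made for them only; others in the source may bear on it.

All three measured compounds share one core, a trans-enone linking a pyrazole-bearing aryl ring to a carbonyl-bearing aryl ring. Compound 2 `COc1cc(-c2cc(/C=C/C(=O)c3ccc(N)cc3)[nH]n2)cc(OC)c1OC` carries three methoxy groups on one ring and an aminophenyl on the carbonyl carbon. In a functional assay on MDA-MB-231 cells (Homo sapiens) for cytotoxicity, read by sulforhodamine B assay, with a stated time of 48 h, tested at 0.01 uM (a lower number here means a stronger effect, a higher number a weaker effect of the compound at the concentration tested), compound 2 gives 109%. Compound 3 `COc1cc(-c2cc(/C=C/C(=O)c3ccc(Cl)c(Cl)c3)[nH]n2)cc(OC)c1OC` differs only at the carbonyl carbon, where a 3,4-dichlorophenyl replaces the 4-aminophenyl, and in this assay compound 3 gives 103%, with the step of a number 6 percentage points lower from compound 2 to compound 3 (within the scatter). Compound 1 `COc1ccc(-c2cc(/C=C/C(=O)c3ccc(N)cc3)[nH]n2)cc1` keeps the aminophenyl but has a single methoxy group, and in this assay compound 1 gives 93%, a number that lies beyond the usual scatter from that of compound 2.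

Compound 4 `COc1ccc(-c2cc(/C=C/C(=O)c3ccc(N)cc3)[nH]n2)cc1OC` is made from compound 2 by one change: hydrogen in place of methoxy on an aromatic carbon. Among the measured compounds shown here, no measured step removes a methoxy group from this ring, so the only guide is the pair of compound 1 and compound 2, whose values show that a ring with fewer methoxy groups gave the lower number. Compound 4 sits between them in its count of methoxy groups, so at most a modest drop is expected, with the step of a number 9 percentage points lower from compound 2 to compound 4 (within the scatter) estimated. In this assay compound 4 is therefore expected to give about 100%, likely between 85% and 115%.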

Compound 4, a percentage reported as activity, at one concentration (the size of the read-out at that concentration, not a potency): 113%
Estimate against measurement, compound 4: 13 percentage points below; the range from low to high includes it.
By their numbers in this assay, from the lowest: compounds 1, 3, 2 and 4 (each within the scatter of the next, the first and the last beyond it).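

Hydrogen in place of methoxy on this aromatic carbon, ortho to a methoxy group and meta to a large group, gives in this assay a number 4 percentage points higher from compound 2 to compound 4 (within the scatter), so at this position the two compounds cannot be told apart. Among the compounds shown here, a different single change on the same ring, methoxy in place of hydrogen, gives a number 20 percentage points higher from compound 1 to compound 4 (beyond the scatter), the first step on this ring that lies clearly outside the scatter. For the compounds shown here, the earlier pair differed in two methoxy groups at once; these steps tie the gap to the one methoxy group that separates compound 1 from compound 4, while the further methoxy group of compound 2 brings no readable difference.

From the compounds shown here alone, whether a hydroxyl group or a chlorine atom on this same carbon would also stay within the scatter remains open, as does whether the 3,4-dichlorophenyl swap would behave the same on the ring of compound 4. Each read-out also comes from a single concentration, so none of these steps speaks to potency, and no measurement at hand explains why the methoxy groups matter as they do.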